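The source may report more compounds than this note shows. Statements on the series, on what has been measured and on what is new or still open speak of the compounds shown alone.

Two compounds of the series carry numbers in an ADME assay on the whole organism (Mus musculus, strain Swiss Webster) for pharmacokinetics, read by LC-MS, at a dose of 50 mg/kg by the oral route; a lower number here means less compound in the circulation, a higher number more compound in the circulation at the dose given. Compound 1 `O=C(Nc1ccc(F)c(-c2nc3ncc(-c4cc(F)ccc4F)cc3[nH]2)c1)N1CCCC1` gives 2800 nM in this assay. Compound 2 `Cc1nc(C)c(C(=O)Nc2ccc(F)c(-c3nc4ncc(-c5ccccc5Cl)cn4n3)c2)o1` gives 39300 nM in this assay. Compound 1 stands lowest of the two, and its gap to compound 2, the nearest, lies beyond the scatter; the two differ in more than one place, so that gap is not tied to any single change and says nothing about any one group.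

Compound 3 `O=C(Nc1ccc(F)c(-c2nc3ncc(-c4ccc(F)c(F)c4)cc3[nH]2)c1)N1CCCC1` has not yet been measured in this assay. It differs from compound 1 as follows: 3,4-difluorophenyl in place of 2,5-difluorophenyl on an aromatic carbon The two compounds have the same atoms, joined differently. Among the measured compounds shown here, no measured pair isolates this change, so its effect on the maximal plasma concentration is not known from the numbers in hand. For the measured compounds named here, with no such pair to lean on, the expected step is a 1.3-fold higher number from compound 1 to compound 3 (0.10 log units; within the scatter), which lies within the scatter, with no direction asserted. Compound 3 is estimated at 3500 nM in this assay, with a range from 1200 nM to 10000 nM.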

Compound 3, maximal plasma concentration: 6670 nM
Compound 3: the middle estimate sits 1.9-fold (0.28 log units) below what was measured; low and high end bracket the measured number.
By their numbers in this assay, from the lowest: compound 1; then compound 3; then compound 2.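

Among the compounds shown here, this is the first reading at this aromatic carbon of a change in one place: in this assay, 3,4-difluorophenyl in place of 2,5-difluorophenyl gives a 2.4-fold higher number from compound 1 to compound 3 (0.38 log units; beyond the scatter) and counts as a modest step. The gap between compound 1 and compound 2 could not be tied to any one group, whereas this pair shows that the fluorine arrangement on this phenyl ring alone shifts the maximal plasma concentration beyond the scatter, although both groups hold the same heavy atoms and neither has a hydrogen-bond donor or acceptor. The data in hand offer no measurement that accounts for this step.

The compounds shown leave open how a plain phenyl, a pyridine ring or a methoxyphenyl at this carbon would read in this assay, and so whether the step reflects something particular to these two fluorine patterns. On these data alone, compound 2 differs from both in more than one place, so whether the same change would give a similar step on its core also remains open.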